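The source may hold more compounds than are shown below. What is called first, only, known or untested is meant among the compounds shown, and "the series" means these compounds.

Measured so far in an ADME assay on HFF cells (Homo sapiens) for cytotoxicity, with a stated time of 8 days; on this read-out lower numbers stand for higher toxicity in this test and higher numbers for lower toxicity in this test:
Compound 1 `CCCCSc1nc(N)nc2c1ncn2/C=C1/CC1(CO)CO` gives > 300000 nM, which is a limit of the assay and not a number.
Compound 2 `CC(C)CSc1nc(N)nc2c1ncn2/C=C1/CC1(CO)CO` gives > 300000 nM, likewise a limit of the assay and not a number.

Compound 2 stands at a limit in this assay. Among the compounds with values here, the only other value shown, that of compound 1, is also a limit, so no number fixes where compound 2 stands relative to any other compound. Within the data shown here, the one measured step, a step that the two limits leave unreadable from compound 1 to compound 2, joins two limits and its size cannot be read. The change to compound 3 `CCCNc1nc(N)nc2c1ncn2/C=C1/CC1(CO)CO` is propylamino in place of isobutylsulfanyl on an aromatic carbon. No measured step covers a change of this kind: the one step shown alters only the chain on the sulfur and keeps the sulfur itself. Among the measured compounds shown here, both values shown sit at the limit of > 300000 nM in this assay, at which 2 of the 2 values shown sit, so the series so far gives no number at all to lean on. For compound 3 no shift beyond the scatter is expected in this assay, and the expected step is a number no higher from compound 2 to compound 3 (the limit leaves the size open). The estimate for compound 3 is 300000 nM, between 100000 nM and 1000000 nM, most likely reported again as a limit.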

Compound 3, half-maximal cytotoxic concentration: > 300000 nM
Compound 3: a limit, no number; the forecaster's own chance of this, stated with the estimate: 75%; the middle value sits exactly at the limit.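

In this assay compound 3 gives > 300000 nM, which is a limit of the assay and not a number. No step among compound 1, compound 2 and compound 3 can be read, because all three stand at the same limit: the limit of > 300000 nM in this assay, at which 3 of the 3 values shown sit.

The compounds shown leave open whether butylsulfanyl, isobutylsulfanyl and propylamino differ at all in this assay.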